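The compounds below may be only part of what the source reports. "The series", "measured", "known", "first", "only" and "open" are said of these compounds alone.

Measured compounds:
- compound 1 `COc1cc2c(Oc3ccc(NC(=O)Nc4cccc(C)c4)cc3)ccnc2cc1OCCCCCCC(=O)NO`: 1240 nM
- compound 2 `COc1cc2c(Oc3ccc(NC(=O)Nc4ccccc4F)cc3)ccnc2cc1OCCCCCCC(=O)NO`: 660 nM
- compound 3 `COc1ccccc1NC(=O)Nc1ccc(Oc2ccnc3cc(OCCCCCCC(=O)NO)c(OC)cc23)cc1`: 6280 nM

These three compounds were tested in a functional assay on MCF7 cells (Homo sapiens) for antiproliferative activity, read by MTT assay; a lower number here means a stronger inhibitor, a higher number a weaker inhibitor. Compound 1 stands second highest of the three numbers: compound 2 is its nearest neighbour at a 1.9-fold lower number from compound 1 to compound 2 (0.27 log units; within the scatter), while compound 3 lies furthest away at a 5.1-fold higher number from compound 1 to compound 3 (0.70 log units; beyond the scatter).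

Compound 4 `COc1cc2c(Oc3ccc(NC(=O)NNC(=O)c4cccc(C)c4)cc3)ccnc2cc1OCCCCCCC(=O)NO` has not yet been measured. It differs from compound 1 in one place: ((3-methylphenyl)carbonyl)amino in place of 3-methylphenyl on an amide-type nitrogen.

Among the measured compounds shown here, none of the measured steps changes the same place in the same way. Compound 1 to compound 2 and compound 1 to compound 3 only swap one ring substituent for another, and compound 2 to compound 3 gives a 9.5-fold higher number from compound 2 to compound 3 (0.98 log units; beyond the scatter). The step to compound 4 instead inserts a ((3-methylphenyl)carbonyl)amino group on the amide-type nitrogen, a change these steps cannot anticipate. With only a loose guide, a modest weakening is expected, of about a 2.0-fold higher number from compound 1 to compound 4 (0.30 log units; within the scatter).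

Compound 4 is therefore estimated at 2500 nM, within a range from 600 nM to 10000 nM.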

Compound 4, half-maximal inhibitory concentration: 5830 nM
Beside the measured number, compound 4's estimate is 2.3-fold (0.37 log units) below it; the measured number falls inside the stated range.
By their numbers in this assay, from the lowest: compounds 2 and 1 (each within the scatter of the next); then compounds 4 and 3 (each within the scatter of the next).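

In this assay, among the compounds shown here, the earlier compounds only exchanged one aromatic ring for another on the amide-type nitrogen, whereas ((3-methylphenyl)carbonyl)amino keeps the 3-methylphenyl ring but adds a carbonyl and a further nitrogen, and this weakens activity, with a 4.7-fold higher number from compound 1 to compound 4 (0.67 log units; beyond the scatter) and an 8.8-fold higher number from compound 2 to compound 4 (0.95 log units; beyond the scatter) both beyond the usual scatter. The step of a 1.1-fold lower number from compound 3 to compound 4 (0.03 log units; within the scatter) lies within the scatter, so this group and the 2-methoxyphenyl of compound 3 reach the same range even though they differ in one place. Nothing measured here bears on why activity falls with this change.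

On these data alone, it remains open whether the loss follows the added carbonyl, the added nitrogen or the two together. Also unanswered is how an acetyl group or a carboxylic acid would behave on the same amide-type nitrogen.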